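The compounds below may be only part of what the source reports. "The series", "measured", "known", "first", "only" and "open" are said of these compounds alone.

Working notes on the series, all read in a functional assay on MCF7 cells (Homo sapiens) for cytotoxicity, in the presence of a further agent that is not named here; a higher number here means that more compound is needed for the effect, a lower number that less compound is needed. Compound 1 `CCCCCCCO[C@@H]1[C@@H](O)[C@@H](OCc2ccccc2)O[C@H](CC(C)C)[C@H]1OC` carries a free hydroxy and gives 7 ug/mL. Compound 2 `CCCCCCCO[C@@H]1[C@@H](OCc2ccccc2)[C@@H](OCc2ccccc2)O[C@H](CC(C)C)[C@H]1OCc1ccc(OC)cc1` gives only > 20 ug/mL, which is a limit of the assay and not a number. Compound 2 therefore stands at the limit of > 20 ug/mL in this assay, at which 1 of the 2 values shown sits, and its true position on the scale is not known.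

Compound 3 `CCCCCCCO[C@@H]1[C@@H](O)[C@@H](OCc2ccccc2)O[C@H](CC(C)C)[C@H]1OCc1ccc(OC)cc1` follows from compound 2 by a single change: hydrogen in place of benzyl on an oxygen on a saturated carbon. This places hydrogen in place of benzyl on an oxygen on a saturated carbon, a change from benzyloxy to hydroxy. Within the data shown here, no measured pair isolates this change, so the expectation leans on compound 1 alone, which has a free hydroxy and reads 7 ug/mL. In this assay a move towards a lower number is expected, probably beyond the usual scatter, though the limit leaves its exact size open. The expected change is an at least 1.8-fold lower number from compound 2 to compound 3 (0.25 log units; that floor lies within the scatter). For compound 3 the estimated value is 11 ug/mL, with an expected range of 5 ug/mL to 20 ug/mL.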

Compound 3, half-maximal effective concentration: 4 ug/mL
Compound 3: middle estimate off by 2.8-fold (0.44 log units), on the high side; the measured number lies below the stated range.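

Among these compounds, the change from benzyloxy to hydroxy now has its own measured pair in this assay, which the earlier compounds lacked, and it gives an at least 5.0-fold lower number from compound 2 to compound 3 (0.69 log units; beyond the scatter). The size of this step is only a floor, as compound 2 is held at a limit of the assay and not at a number: the limit of > 20 ug/mL in this assay, at which 1 of the 3 values shown sits. The second step, 4-methoxyphenyl in place of hydrogen on a saturated chain carbon bound to an oxygen on a saturated carbon, gives a 1.8-fold lower number from compound 1 to compound 3 (0.24 log units; within the scatter), so with the free hydroxy present, compound 1 and compound 3 cannot be told apart in this assay.

On these data alone, how far the true value of compound 2 lies from that of compound 3 stays open, as does whether the free hydroxy itself is what matters or whether an amine at the same place would read the same. Also open, as far as these compounds go, is whether the remaining benzyl group and the heptyl chain contribute to the reading, which a hydroxy in place of that benzyloxy or a longer chain would address.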